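Notes on the shared core: compound 2 toward compound 4

This account rests on a few compounds, and the source may have more. Where it says the series, first, only, none or still open, it means among the compounds named here.

Three compounds have been run in an in vitro functional assay on CHO-CREluc cells for antagonist activity at growth hormone secretagogue receptor type 1 (Homo sapiens), read by a luciferase reporter, with a stated time of 4 h; a higher number here means a weaker inhibitor, a lower number a stronger inhibitor. Compound 1 `CN(C)CCN(C)CC(=O)NC1(c2ccc(Cl)cc2)C(=O)Nc2cc(Cl)c(Cl)cc21` gives only a limit of the assay, > 10000 nM. Compound 2 `Cc1cc2c(cc1Cl)NC(=O)C2(NC(=O)CN1CCN(c2ccncc2)CC1)c1ccc(Cl)cc1` likewise gives only a limit, > 10000 nM. Among the measured compounds shown here, compound 3 `CN1CCN(CC(=O)NC2(c3ccc(C(C)(C)C)cc3)C(=O)Nc3cc(Cl)c(Cl)cc32)CC1` is the one compound with a number, 1470 nM. Compound 2 thus sits at the limit of > 10000 nM in this assay, at which 2 of the 3 values shown sit, and only compound 3 lies under that ceiling. For the measured compounds named here, no two of the measured compounds differ in a single place, so no measured step is available to lean on.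

Compound 4 `CCN1CCN(CC(=O)NC2(c3ccc(Cl)cc3)C(=O)Nc3cc(Cl)c(C)cc32)CC1` differs from compound 2 in one place: ethyl in place of pyridin-4-yl on an amine nitrogen in a ring. Without a measured step of this kind, the expectation for compound 4 in this assay is a modest move toward measurable inhibition, roughly an at least 2.5-fold lower number from compound 2 to compound 4 (0.39 log units; beyond the scatter), small enough that a reading at the limit again would not surprise. Compound 4 is estimated at 4000 nM, with a range from 1000 nM to 20000 nM.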

Compound 4, half-maximal inhibitory concentration: 129 nM
Compound 4: middle estimate off by 31-fold (1.49 log units), on the high side; measured number outside the range, below it.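

In this assay, the amine nitrogen in the ring is a place where a single change moves compound 2 from a limit of the assay to a measured number: ethyl in place of pyridin-4-yl gives an at least 77-fold lower number from compound 2 to compound 4 (1.88 log units; beyond the scatter). Among the compounds shown here, this is the first single-place step, and it shows that a small group without a ring on this nitrogen is compatible with clear inhibition. The step is only a lower bound because compound 2 gives no number: the limit of > 10000 nM in this assay, at which 2 of the 4 values shown sit.

Going by these compounds, whether the gain depends on ethyl itself or only on the absence of the pyridin-4-yl ring stays open, and propyl, cyclopropyl or 2-hydroxyethyl on the same nitrogen would help separate the two. For the compounds shown here, no step yet isolates any other place on the shared core.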